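This account rests on a few compounds, and the source may have more. Where it says the series, first, only, none or still open, it means among the compounds named here.

Compound 1 `CC(C)=CC[C@@H](OCCO)C1=CC(=O)c2c(O)ccc(O)c2C1=O`: 18600 nM
Compound 2 `CCC(C)(O)CC(=O)O[C@H](CC=C(C)C)C1=CC(=O)c2c(O)ccc(O)c2C1=O`: 25200 nM

In a functional assay on HeLa cells (Homo sapiens) for cytotoxicity, read by MTT assay (on this read-out higher numbers stand for weaker inhibition and lower numbers for stronger inhibition), compound 2 gives 25200 nM. Going by the values given here, with only two compounds measured, its sole neighbour is compound 1, and the two values lie within the scatter of each other.

Compound 3 `CCCCC(C)(O)CC(=O)O[C@H](CC=C(C)C)C1=CC(=O)c2c(O)ccc(O)c2C1=O` keeps the shared core and alters only the side chain of compound 2. The change is ethyl in place of hydrogen on a saturated chain carbon, three bonds along the chain from an oxygen on a saturated carbon, which lengthens the ethyl to a butyl.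

Among the compounds with values here, only one measured step bears on this: a 1.4-fold higher number from compound 1 to compound 2 (0.13 log units; within the scatter). That step replaces the whole group on the oxygen, so it is indirect evidence for the smaller change made here. Even so, the larger swap left the number within the scatter. Within the data shown here, no measured pair shows what lengthening this chain does, so the direction cannot be read from the data.

No shift beyond the scatter is therefore expected, and the estimated step is a 1.3-fold lower number from compound 2 to compound 3 (0.10 log units; within the scatter). For compound 3 the expected value is 20000 nM, with an estimated range of 9000 nM to 40000 nM.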

Compound 3, half-maximal inhibitory concentration: 60600 nM
Beside the measured number, compound 3's estimate is 3.0-fold (0.48 log units) below it, outside the stated range (above it).
By their numbers in this assay, from the lowest: compounds 1 and 2 (each within the scatter of the next); then compound 3.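

In this assay, going by these compounds alone, this position is the first where a change moves the number beyond the scatter: ethyl in place of hydrogen on a saturated chain carbon, which lengthens the ethyl to a butyl, gives a 2.4-fold higher number from compound 2 to compound 3 (0.38 log units; beyond the scatter), meaning weaker inhibition. This shows that the far end of the side chain matters, even though replacing the whole group on the oxygen had given only a 1.4-fold higher number from compound 1 to compound 2 (0.13 log units; within the scatter), which lies within the scatter; taken from the simpler 2-hydroxyethyl group, the full change to the (2-hydroxy-2-methylhexyl)carbonyl group gives a 3.3-fold higher number from compound 1 to compound 3 (0.51 log units; beyond the scatter). Nothing available here explains why the longer chain goes with the higher number.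

One lengthening step cannot show whether the number climbs steadily with chain length, so a propyl chain in the same place, or a hexyl chain, would be needed to tell a trend from a single jump. On these data alone, it also remains open whether the loss belongs to added carbons as such, which a butyl chain ending in an amine or a carboxylic acid could begin to test.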